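The source may report more compounds than this note shows. Statements on the series, on what has been measured and on what is new or still open speak of the compounds shown alone.

Measured so far:
compound 1 `COc1cc(Cl)cc(-c2nn(-c3cccc(NC(=O)c4ccc(Cl)c(Cl)c4)c3)cc2-c2ccncc2)c1` — 80.1%
compound 2 `COc1cc(Cl)cc(-c2nn(-c3cccc(NC(=O)Nc4cc(C(F)(F)F)cc(C(F)(F)F)c4)c3)cc2-c2ccncc2)c1` — 6.84%

In a functional assay on SK-OV-3 cells (Homo sapiens) for inhibition, read by sulforhodamine B assay, with a stated time of 48 h, tested at 10 uM (a lower number here means a stronger effect, a higher number a weaker effect of the compound at the concentration tested), compound 2 gives 6.84%, the lowest of the two numbers. Compound 1 gives 80.1%, a gap beyond the usual scatter. Compound 3 `COc1cc(Cl)cc(-c2nn(-c3cccc(NC(=O)Nc4cccc(C(F)(F)F)c4)c3)cc2-c2ccncc2)c1` is not yet measured. The change from compound 2 to compound 3: hydrogen in place of trifluoromethyl on an aromatic carbon. Among the compounds with values here, no step between measured compounds covers this change, so the expectation rests on compound 2 alone. The number is expected to rise moderately, with a number 23.2 percentage points higher from compound 2 to compound 3 (beyond the scatter) as the estimated step, the effect weakening but not lost. Compound 3 is estimated at 30%, within 8% to 65%.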

Compound 3, a percentage reported as activity, at one concentration (the size of the read-out at that concentration, not a potency): 14.2%
Compound 3: middle estimate off by 15.8 percentage points, on the high side, and the stated range covers the measured number.
By their numbers in this assay, from the lowest: compounds 2 and 3 (each within the scatter of the next); then compound 1.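

In this assay the second trifluoromethyl group can give way to hydrogen with no readable loss, a number 7.4 percentage points higher from compound 2 to compound 3 (within the scatter), so the two groups are not told apart at this position. Compound 3 also shows that (3-(trifluoromethyl)phenyl)amino in place of 3,4-dichlorophenyl on the carbonyl carbon carries a large gain on its own, a number 65.9 percentage points lower from compound 1 to compound 3 (beyond the scatter), without needing the second trifluoromethyl group. No measurement at hand accounts for either step.

Still open, going by these compounds, is how the phenyl ring without any trifluoromethyl group would read, and whether an amine or a carboxylic acid at this position would hold the effect.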